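Two limits and a nitrile swap

A few compounds are considered here, and "the series" means these few. Any claim that something is new, unique, unknown or untested is made for them only; others in the source may bear on it.

Compound 1 `N#CCCN(Cc1ccco1)S(=O)(=O)c1ccc(Br)cc1` gives > 180000 nM
Compound 2 `Cc1ccc(S(=O)(=O)N(CCC#N)Cc2ccco2)cc1` gives > 219000 nM

In an ADME assay on MDCK cells (Canis lupus familiaris) for cytotoxicity, read by MTT assay, with a stated time of 24 h (on this read-out lower numbers stand for higher toxicity in this test and higher numbers for lower toxicity in this test), compound 2 reaches > 219000 nM as a limit only. Compound 1 likewise gives > 180000 nM as a limit. Compound 3 `N#CCCN(Cc1ccco1)S(=O)(=O)c1ccc(C#N)cc1` differs from compound 2 by cyano in place of methyl on an aromatic carbon, para to a large group. Among the measured compounds shown here, with a step that the two limits leave unreadable from compound 1 to compound 2 as the only measured step and no size to read from it, no step beyond the scatter is expected in this assay for this change. The expected change is an at least 1.0-fold lower number from compound 2 to compound 3 (0.01 log units; that floor lies within the scatter) in this estimate. Compound 3 is estimated at 210000 nM with a range from 100000 nM to 400000 nM.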

Compound 3, half-maximal cytotoxic concentration: > 211000 nM
Compound 3 was reported as a limit; the forecaster's own chance of this, stated with the estimate: 85%; at least 1.0-fold (0.00 log units) between middle value and limit.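

Among the compounds shown here, compound 3 gives > 211000 nM, a limit, and compound 1 and compound 2 are also reported only as limits, so no step among the three can be read. From the compounds shown here alone, whether bromo, methyl or cyano on the aromatic carbon changes the half-maximal cytotoxic concentration at all remains open.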